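A few compounds are considered here, and "the series" means these few. Any claim that something is new, unique, unknown or untested is made for them only; others in the source may bear on it.

Working notes on the series, read in a functional assay on the whole organism (strain Sprague-Dawley) for inhibition, with Rattus norvegicus as the target, with a stated time of 10 min; a lower number here means that less compound is needed, a higher number that more compound is needed for the effect. Compound 1 `CCCCCOc1ccccc1-c1ncc(C(=O)OCC)c(=O)[nH]1`, which carries ethoxycarbonyl, gives 2 mg/kg. Compound 2 `COc1nc(-c2ccccc2)ncc1C(=O)O`, which carries carboxy, has a limit and not a number: > 10 mg/kg. Compound 3 `CCOC(=O)c1cnc(-c2ccccc2)nc1OC` comes from compound 2 by a single change, ethyl in place of hydrogen on an oxygen next to a carbonyl group, so that carboxy becomes ethoxycarbonyl. For the measured compounds named here, no measured step covers this change, so the expectation rests on little. Compound 1 shares the ethoxycarbonyl group and gives 2 mg/kg, but it differs from compound 3 elsewhere, so only a modest gain is expected. The expected change, an at least 1.2-fold lower number from compound 2 to compound 3 (0.09 log units; that floor lies within the scatter), points toward less compound needed in this assay. For compound 3 the estimate is 8 mg/kg, with an expected range of 2.5 mg/kg to 25 mg/kg.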

Compound 3, dose for 50% inhibition: > 5 mg/kg
Compound 3 was reported as a limit; the forecaster's own chance of this, stated with the estimate: 55%; the middle value does not contradict the limit.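

In this assay compound 2 and compound 3 are both reported only as limits, and no step can be read between them. The compounds shown leave open whether ethyl in place of hydrogen on an oxygen next to a carbonyl group changes the dose needed.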